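Removing the Fluorophenyl Arm from a Thiazole Hydroxamate

The source may hold more compounds than are shown below. What is called first, only, known or untested is meant among the compounds shown, and "the series" means these compounds.

compound 1 `CC(C)(NC(=O)c1nc(-c2nccs2)sc1C1CC1)c1ccc(C(=O)NO)cc1`: 148 nM
compound 2 `C[C@H](NC(=O)c1nc(-c2ncc(-c3ccc(F)cc3)s2)sc1C1CC1)c1ccc(C(=O)NO)cc1`: 2.02 nM

Both were tested in an assay on cells for inhibition of protein deacetylase HDAC6 (Homo sapiens), read by fluorescence, with a stated time of 24 h; on this read-out lower numbers stand for stronger inhibition and higher numbers for weaker inhibition. Compound 2 gives the lowest number of the two; compound 1 lies far higher, beyond the usual scatter, though these two differ in more than one place. On these data alone, compound 3 `C[C@H](NC(=O)c1nc(-c2nccs2)sc1C1CC1)c1ccc(C(=O)NO)cc1` is untested. It keeps compound 2 except for one change: hydrogen in place of 4-fluorophenyl on an aromatic carbon. A clear weakening is expected because compound 1 without that aryl group gives 148 nM. The estimated step of a 12-fold higher number from compound 2 to compound 3 (1.09 log units; beyond the scatter) is expected to exceed the scatter. For compound 3 an inhibitory concentration of 25 nM is expected, within 6 nM to 100 nM.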

Compound 3, half-maximal inhibitory concentration: 14 nM
Estimate against measurement, compound 3: 1.8-fold (0.25 log units) above; the range from low to high includes it.
By their numbers in this assay, from the lowest: compound 2; then compound 3; then compound 1.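

In this assay, putting hydrogen in place of 4-fluorophenyl on this aromatic carbon, next to the ring sulfur, gives a real loss (a 6.9-fold higher number from compound 2 to compound 3 (0.84 log units; beyond the scatter)), so the aryl arm contributes to the stronger inhibition in this pair. The arm is not essential, however: without it, compound 3 still gives 14 nM. No measurement shown explains this difference. On these data alone, what a plain phenyl, a methyl or an amine on this carbon would give remains open, as does how much of the step belongs to the fluorine rather than the ring.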